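The compounds below may be only part of what the source reports. "The series", "measured", "known", "first", "only" and "open" are said of these compounds alone.

Working notes on the series in an assay on isolated protein for inhibition of Nicotinamide phosphoribosyltransferase (Homo sapiens), read by fluorescence, with stated times of 5 min and 15 min; a lower number here means a stronger inhibitor, a higher number a weaker inhibitor. Compound 1 `Nc1ccccc1NC(=O)c1ccc(CNC(=O)c2cc3cccnc3[nH]2)cc1` returns only a limit in this assay, > 2000 nM. Compound 2 `Nc1ccccc1NC(=O)c1ccc(Cn2cc(-c3ccc(NC(=O)NCc4cccnc4)cc3)nn2)cc1`, built around a different linker between the two ends of the molecule, gives 18 nM in this assay. Compound 3 `Cc1ccc(CNC(=S)Nc2ccc(C(=O)Nc3ccccc3N)cc2)cn1`, carrying a thiourea in place of the amide, also returns only a limit in this assay, > 2000 nM. Two of the three measurements therefore sit at the limit of > 2000 nM in this assay, at which 2 of the 3 values shown sit, and compound 2 is the single one that does not. Compound 1 thus stands with the weaker pair, without a number of its own.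

Compound 4 `Nc1ccccc1NC(=O)c1ccc(CNC(=O)c2ccc3cncn3c2)cc1` is not yet measured. It differs from compound 1 by a group of 9 heavy atoms (7 carbon, 2 nitrogen; one five-membered aromatic ring with 2 hetero atoms, one six-membered aromatic ring with 1 hetero atom) in place of a group of 9 heavy atoms (7 carbon, 2 nitrogen; one five-membered aromatic ring with 1 hetero atom, one six-membered aromatic ring with 1 hetero atom), on a carbonyl carbon; that is, a group of 9 heavy atoms (7 carbon, 2 nitrogen; one five-membered aromatic ring with 2 hetero atoms, one six-membered aromatic ring with 1 hetero atom) in place of a group of 9 heavy atoms (7 carbon, 2 nitrogen; one five-membered aromatic ring with 1 hetero atom, one six-membered aromatic ring with 1 hetero atom), on a carbonyl carbon, the entering group bringing no hydrogen-bond donor where the leaving group had one. Within the data shown here, no measured pair in the set shares this change, so no step size can be read off. The expected step is a step that the limit leaves unreadable from compound 1 to compound 4, nothing beyond the scatter in either direction, and a further limit rather than a number is expected because two of three values already sit at the limit of > 2000 nM in this assay, at which 2 of the 3 values shown sit. Compound 4 is estimated at 4000 nM, with a range from 1200 nM to 20000 nM.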

Compound 4, half-maximal inhibitory concentration: > 2000 nM
Compound 4: a limit, no number; the forecaster's own chance of this, stated with the estimate: 70%; the middle value does not contradict the limit.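

Among these compounds, compound 1 and compound 4 both return only a limit in this assay, so no step between them can be read. The compounds shown leave open whether exchanging the group on the carbonyl carbon changes inhibition at all, and which single structural change separates compound 2 from the compounds that return limits.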